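A few compounds are considered here, and "the series" means these few. Any claim that something is new, unique, unknown or untested is made for them only; others in the source may bear on it.

Measured so far in a functional assay on MDA-MB-231 cells (Homo sapiens) for inhibition, read by MTT assay, with a stated time of 72 h; a higher number here means a weaker inhibitor, a lower number a stronger inhibitor:
- compound 1 `CC(C)[C@H](NC(=O)c1cc(Cl)ccc1OCCN)C(=O)Nc1ccc([N+](=O)[O-])cc1Cl` gives > 10000 nM (a limit)
- compound 2 `CC(C)[C@H](NC(=O)c1cc(Cl)ccc1OCCNC(=O)O)C(=O)Nc1ccc([N+](=O)[O-])cc1Cl` gives > 10000 nM (a limit)
- compound 3 `CSCC[C@H](NC(=O)c1cc(Cl)ccc1OCCN)C(=O)Nc1ccc([N+](=O)[O-])cc1Cl` gives > 10000 nM (a limit)

Compound 1 stands at a limit and not at a number, so it has no readable place on the scale. Going by the values given here, it shares that place with the other two compounds, as the series so far sits at the limit of > 10000 nM in this assay, at which 3 of the 3 values shown sit (no number among them).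

Compound 4 `CC(C)[C@H](NC(=O)c1cc(Cl)ccc1OCCN)C(=O)Nc1ccc(C(F)(F)F)cc1Cl` keeps the core of compound 1 and changes one group: trifluoromethyl in place of nitro on an aromatic carbon (trifluoromethyl in place of nitro on an aromatic carbon, para to a large group).

The nearest measured steps are a step that the two limits leave unreadable from compound 1 to compound 2 and a step that the two limits leave unreadable from compound 1 to compound 3 and neither gives a size. Among the compounds with values here, neither of them alters the nitro group, and no measured compound lacks it, so the data hold no direct reading of this change.

The expectation in this assay rests on compound 1 at > 10000 nM (a limit) and is for no readable change in either direction. The expected step is a step that the limit leaves unreadable from compound 1 to compound 4 and this estimate is loose. For compound 4 the estimated value is 15000 nM with an expected range from 5000 nM to 40000 nM in this estimate.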

Compound 4, half-maximal inhibitory concentration: 5440 nM
The estimate for compound 4 lay 2.8-fold (0.44 log units) above the measured number, within the range that was stated.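

In this assay, trifluoromethyl in place of nitro on the aromatic carbon para to a large group gives an at least 1.8-fold lower number from compound 1 to compound 4 (0.26 log units; that floor lies within the scatter). That step is a floor taken from a limit, so it fixes no size, and on its own it does not separate the two groups beyond the scatter. What the result adds is that, with the core of compound 1 otherwise unchanged, a compound without the nitro group reaches a number on the scale, whereas the three compounds carrying nitro stay at a limit: the limit of > 10000 nM in this assay, at which 3 of the 4 values shown sit.

Going by these compounds, the steps from compound 1 to compound 2 and to compound 3 cannot be read, and it remains open whether the carboxy or the 2-(methylsulfanyl)ethyl change would shift a number once trifluoromethyl is in place. Also open, on these data alone, is how a nitrile, a methyl group or a bromo group at this same position would stand against trifluoromethyl, and so whether the number of compound 4 is particular to trifluoromethyl or follows from the loss of nitro alone.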